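From 3,5-Dimethylphenyl to Isobutyl on Compound 1

The source may hold more compounds than are shown below. What is called first, only, known or untested is meant among the compounds shown, and "the series" means these compounds.

In an ADME assay on HepG2 cells (Homo sapiens) for cytotoxicity, read by luminescence, CellTiter-Glo and ATP content, with a stated time of 72 h (a lower number here means that less compound is needed, a higher number that more compound is needed for the effect), compound 1 `Cc1cc(C)cc(Cc2ccc3c(NCCCNCc4ccco4)ccnc3c2)c1` gives 6270 nM. This lies within the scatter of compound 2 `COc1ccc(Oc2ccc3c(NCCCNCc4cc(F)ccc4OC)ccnc3c2)cc1`, which gives 7000 nM. Compound 3 `COc1cccc(CNCCCNc2ccnc3cc(Cc4cc(C)cc(C)c4)ccc23)c1O` gives 2680 nM, the lowest of the three numbers.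

Compound 4 `CC(C)CCc1ccc2c(NCCCNCc3ccco3)ccnc2c1` keeps the furan-2-yl group of compound 1 and differs elsewhere: isobutyl in place of 3,5-dimethylphenyl on a saturated chain carbon bound to an aromatic carbon. Isobutyl stands in place of 3,5-dimethylphenyl on a saturated chain carbon bound to an aromatic carbon.

Among the measured compounds shown here, the only measured step, a 2.3-fold lower number from compound 1 to compound 3 (0.37 log units; beyond the scatter), is modest and replaces furan-2-yl with 2-hydroxy-3-methoxyphenyl. It does not touch the place that changes here, so it offers only a rough guide to size and none to direction. For the measured compounds named here, no measured compound shows what losing the 3,5-dimethylphenyl group does in this assay. A small rise is tentatively expected, with no firm expectation of a change beyond the scatter. The estimated step is a 1.4-fold higher number from compound 1 to compound 4 (0.13 log units; within the scatter). For compound 4 the estimate is 8500 nM, with an expected range from 3500 nM to 20000 nM.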

Compound 4, half-maximal effective concentration: 11200 nM
Compound 4: the middle estimate sits 1.3-fold (0.12 log units) below what was measured; measured number inside the range.
By their numbers in this assay, from the lowest: compound 3; then compounds 1, 2 and 4 (each within the scatter of the next).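

Replacing 3,5-dimethylphenyl with isobutyl on a saturated chain carbon bound to an aromatic carbon gives a 1.8-fold higher number from compound 1 to compound 4 (0.25 log units; within the scatter) in this assay. Among the compounds shown here, this is the first reading at this position, and it shows that the aromatic ring of the 3,5-dimethylphenyl group can give way to an open carbon chain without a step beyond the scatter, on a core that keeps the furan-2-yl group. No evidence is available that bears on this result.

The compounds shown leave open whether a cyclohexyl group or an unsubstituted phenyl at this place would read the same way as either group tested. Going by these compounds, it also remains open whether 2-hydroxy-3-methoxyphenyl in place of furan-2-yl would give a similar step with isobutyl present.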